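Replacing Oxolan-3-yl with Oxetan-2-yl: An Expected Clearance

The source may hold more compounds than are shown below. What is called first, only, known or untested is meant among the compounds shown, and "the series" means these compounds.

Measured in an in vitro ADME assay on microsomes from liver (Homo sapiens) for metabolic stability, read by HPLC; on this read-out lower numbers stand for slow clearance and higher numbers for fast clearance:
- compound 1 `CC1(C)C[C@H](CN([C@H](CCC(F)(F)F)C(N)=O)S(=O)(=O)c2ccc(Cl)cc2)O1`: 29 mL/min/kg
- compound 2 `NC(=O)[C@@H](CCC(F)(F)F)N(C[C@@H]1COCCO1)S(=O)(=O)c1ccc(Cl)cc1`: 117 mL/min/kg
- compound 3 `NC(=O)[C@@H](CCC(F)(F)F)N(C[C@@H]1CCOC1)S(=O)(=O)c1ccc(Cl)cc1`: 69.8 mL/min/kg

Compound 3 holds the second highest of the three numbers. The step from its nearest neighbour is a 1.7-fold lower number from compound 2 to compound 3 (0.22 log units; within the scatter). The step from its furthest neighbour is a 2.4-fold higher number from compound 1 to compound 3 (0.38 log units; beyond the scatter).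

The next structure is compound 4 `NC(=O)[C@@H](CCC(F)(F)F)N(C[C@H]1CCO1)S(=O)(=O)c1ccc(Cl)cc1`, which has oxetan-2-yl in place of oxolan-3-yl on a saturated chain carbon bound to a sulfonamide nitrogen. Going by the values given here, no measured compound carries this exact group. The closest evidence is compound 1, with its 4,4-dimethyloxetan-2-yl, and the two steps leading away from it are modest: a 2.4-fold higher number from compound 1 to compound 3 (0.38 log units; beyond the scatter) and a 4.0-fold higher number from compound 1 to compound 2 (0.61 log units; beyond the scatter). Compound 4 lacks the two methyl groups of compound 1, so these steps offer only partial guidance. A small fall in this assay is therefore expected, with no change beyond the scatter. The expected step is a 1.3-fold lower number from compound 3 to compound 4 (0.10 log units; within the scatter). For compound 4 the estimated value is 55 mL/min/kg, with an expected range of 28 mL/min/kg to 110 mL/min/kg.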

Compound 4, clearance: 63.8 mL/min/kg
Beside the measured number, compound 4's estimate is 1.2-fold (0.06 log units) below it; the range from low to high includes it.
By their numbers in this assay, from the lowest: compound 1; then compounds 4, 3 and 2 (each within the scatter of the next).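

In this assay, the bare oxetan-2-yl group sits with the larger rings at this place, on a saturated chain carbon bound to a sulfonamide nitrogen: the data give a 1.1-fold lower number from compound 3 to compound 4 (0.04 log units; within the scatter) and a 1.8-fold lower number from compound 2 to compound 4 (0.26 log units; within the scatter) for the two comparisons. Going by these compounds alone, the only step beyond the scatter is a 2.2-fold higher number from compound 1 to compound 4 (0.34 log units; beyond the scatter) and it removes just the two methyl groups, so the low number of compound 1 goes with 4,4-dimethyloxetan-2-yl and not with the four-membered ring as such. Nothing measured here accounts for this difference.

As far as these compounds go, it remains open whether one methyl group on the oxetan-2-yl ring would give a step of similar size, or whether two methyl groups on the oxolan-3-yl ring would. Also open, from the compounds shown here alone, is how an open ether chain such as methoxyethyl would compare at this place.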